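This account rests on a few compounds, and the source may have more. Where it says the series, first, only, none or still open, it means among the compounds named here.

Measured so far:
Compound 1 `O=C(N/N=C/c1cccs1)c1ccc(-c2nc3ccccc3s2)cc1` gives 8480 nM in an assay on isolated protein for inhibition of Maltase-glucoamylase (Homo sapiens), with a stated time of 15 min; on this read-out higher numbers stand for weaker inhibition and lower numbers for stronger inhibition.
Compound 2 `O=C(N/N=C/c1ccncc1)c1ccc(-c2nc3ccccc3s2)cc1` is reported as "not active" (no number reported) in this assay, with no number attached.

Within the data shown here, compound 1 thus holds the only number in this assay; the one other entry, compound 2, carries no figure. Compound 3 `COc1cc(/C=N/NC(=O)c2ccc(-c3nc4ccccc4s3)cc2)ccc1O` has not yet been tested in this assay. It differs from compound 1 in one place 4-hydroxy-3-methoxyphenyl in place of thiophen-2-yl on a carbon with a double bond to nitrogen — 4-hydroxy-3-methoxyphenyl in place of thiophen-2-yl on a carbon with a double bond to nitrogen. Among the measured compounds shown here, no measured pair shows a comparable step, so the expectation rests on compound 1 alone: a modest step in this assay, possibly none beyond the scatter, is expected, a 1.4-fold lower number from compound 1 to compound 3 (0.15 log units; within the scatter). Compound 3 is accordingly estimated at 6000 nM, in a range from 1500 nM to 30000 nM.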

Compound 3, half-maximal inhibitory concentration: 53300 nM
For compound 3 the middle estimate is 8.9-fold (0.95 log units) below the measured one, outside the stated range (above it).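

On the carbon with a double bond to nitrogen, 4-hydroxy-3-methoxyphenyl in place of thiophen-2-yl is not a neutral exchange in this assay: the read-out moves by a 6.3-fold higher number from compound 1 to compound 3 (0.80 log units; beyond the scatter), so this position responds to the group it carries. Thiophen-2-yl is the stronger of the two groups with a number here. The data offer no measured explanation for this weakening. From the compounds shown here alone, it remains open whether the change of ring or the hydroxy and methoxy groups carry the step. A plain phenyl or an aminophenyl at this position would help separate these contributions.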